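Extending the hydroxylated amide side chain in the series

The source may hold more compounds than are shown below. What is called first, only, known or untested is meant among the compounds shown, and "the series" means these compounds.

In a functional assay on MCF7 cells (Homo sapiens) for antiproliferative activity, read by MTT assay, with a stated time of 24 h (on this read-out higher numbers stand for weaker inhibition and lower numbers for stronger inhibition), compound 1 `CCn1c(C(=O)NCC(=O)OC)ccc1C(CC)(CC)c1ccc(OCS(=O)(=O)c2ccccc2)c(C)c1` gives > 50000 nM as a limit of the assay and not a number. Compound 2 `CCn1c(C(=O)NCCNC(=O)OC(C)(C)C)ccc1C(CC)(CC)c1ccc(OCS(=O)(=O)c2ccccc2)c(C)c1` gives > 50000 nM as the same limit. Within the data shown here, compound 3 `CCn1c(C(=O)N[C@H](CO)CCO)ccc1C(CC)(CC)c1ccc(OCS(=O)(=O)c2ccccc2)c(C)c1` gives 28500 nM as the only actual number so far, while the limit of > 50000 nM in this assay, at which 2 of the 3 values shown sit, holds the other two values. Compound 4 `CCn1c(C(=O)N[C@H](CO)CCCO)ccc1C(CC)(CC)c1ccc(OCS(=O)(=O)c2ccccc2)c(C)c1` differs from compound 3 by hydroxymethyl in place of hydroxy on a saturated chain carbon, three bonds along the chain from an amide-type nitrogen and so reads as 2-hydroxyethyl to 3-hydroxypropyl on that chain. Among the measured compounds shown here, two measured steps bear on this, an at least 1.7-fold lower number from compound 1 to compound 3 (0.24 log units; that floor lies within the scatter) and an at least 1.7-fold lower number from compound 2 to compound 3 (0.24 log units; that floor lies within the scatter), and each replaces the whole amide side chain, so neither gives the size of this smaller change. No step beyond the scatter is therefore expected in this assay, although a result reported only as a limit remains possible. The expected step is a 1.1-fold higher number from compound 3 to compound 4 (0.02 log units; within the scatter) in size. For compound 4 the estimated value is 30000 nM with an expected range of 14000 nM to 50000 nM as its ends.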

Compound 4, half-maximal inhibitory concentration: 31400 nM
For compound 4 the middle estimate is 1.0-fold (0.02 log units) below the measured one; the range from low to high includes it.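

In this assay, hydroxymethyl in place of hydroxy on a saturated chain carbon, three bonds along the chain from an amide-type nitrogen, gives a 1.1-fold higher number from compound 3 to compound 4 (0.04 log units; within the scatter), so 2-hydroxyethyl and 3-hydroxypropyl at this place cannot be told apart on this read-out. Compound 4, like compound 3, gives a number and not a limit, with an at least 1.5-fold lower number from compound 2 to compound 4 (0.20 log units; that floor lies within the scatter) and an at least 1.5-fold lower number from compound 1 to compound 4 (0.20 log units; that floor lies within the scatter), although each of these steps replaces the whole amide side chain. These two steps are floors only, since compound 1 and compound 2 each stand at a limit of the assay and not at a number: the limit of > 50000 nM in this assay, at which 2 of the 4 values shown sit.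

Going by these compounds, whether 4-hydroxybutyl at this place would move the number beyond the scatter remains open. The same holds for an amine or a carboxylic acid in place of the hydroxy.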